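The source may report more compounds than this note shows. Statements on the series, on what has been measured and on what is new or still open speak of the compounds shown alone.

Measured so far:

- compound 1, `Cc1ncsc1C(=O)NCCC1CCN(S(=O)(=O)NC(=O)NC[C@@H]2C[C@@H]3C=C[C@@H]2C3)CC1`: 11%
- compound 2, `COc1ccc(C(=O)NCCC2CCN(S(=O)(=O)NC(=O)NC[C@@H]3C[C@@H]4C=C[C@@H]3C4)CC2)cn1`: 11%

In a functional assay on the whole organism (blood) with Rattus norvegicus as the target, with stated times of 24 h and 1 h, at a dose of 5 mg/kg by the intraperitoneal route (on this read-out higher numbers stand for a stronger effect at the one dose given and lower numbers for a weaker effect), compound 2 gives 11%, and compound 1 gives 11%, so compound 2 stands level with compound 1 within the scatter of this read-out. For the measured compounds named here, the one step measured so far, no change at the digits printed from compound 1 to compound 2 (within the scatter), replaced one aryl group on the carbonyl carbon with another and left the read-out unchanged.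

Compound 3, `COc1ccncc1C(=O)NCCC1CCN(S(=O)(=O)NC(=O)NC[C@@H]2C[C@@H]3C=C[C@@H]2C3)CC1`, carries the same atoms as compound 2 joined differently: 4-methoxypyridin-3-yl in place of 6-methoxypyridin-3-yl on a carbonyl carbon. Going by the values given here, the single step that bears on this change is the one from compound 1 to compound 2, which was flat; it suggests that the group on this carbonyl carbon can be exchanged without moving the read-out, though a shift of a methoxy group around one ring has not itself been tested. On that basis the step is expected to be no change at the digits printed from compound 2 to compound 3 (within the scatter), with no movement beyond the scatter. Compound 3 is therefore estimated at 11%, within a range of 0% to 25%.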

Compound 3, a percentage reported as activity, at one dose (the size of the read-out at that dose, not a potency): 14%
Estimate against measurement, compound 3: 3 percentage points below; the measured number falls inside the stated range.
By their numbers in this assay, from the lowest: compounds 1, 2 and 3 (each within the scatter of the next).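

In this assay the read-out shows a number 3 percentage points higher from compound 2 to compound 3 (within the scatter) when 4-methoxypyridin-3-yl takes the place of 6-methoxypyridin-3-yl on a carbonyl carbon whose other neighbour is an amide-type nitrogen. For the compounds shown here, this is the first comparison at this position of two groups with the same atoms joined differently, and this assay does not separate them at its one dose. The read-out also shows a number 3 percentage points higher from compound 1 to compound 3 (within the scatter) when the same 4-methoxypyridin-3-yl takes the place of 4-methyl-1,3-thiazol-5-yl, so the three six-membered or five-membered aromatic groups seen here all lie within the scatter of one another, and nothing available explains this.

Going by these compounds, all three compounds carry an aromatic ring on this carbonyl carbon, so it remains open whether a group of another kind there, such as a saturated cyclohexyl ring, a carboxylic acid or an amine, would move the read-out beyond the scatter. On these data alone, it also remains open whether these three compounds would still read alike at another dose or time, since a single-dose percentage is not a potency.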